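The source may report more compounds than this note shows. Statements on the series, on what has been measured and on what is new or still open speak of the compounds shown alone.

In a functional assay on MKN-74 cells (Homo sapiens) for antiproliferative activity, with a stated time of 24 h (a higher number here means a weaker inhibitor, a lower number a stronger inhibitor), compound 1 (`NC(=O)c1c(NC(=O)c2ccc(C(F)(F)F)cc2)sc2c1CCN(Cc1ccc(Cl)cc1)C2`) reads > 50000 nM as a limit of the assay and not a number. Among the measured compounds shown here, compound 2 (`NC(=O)c1c(NC(=O)c2ccc(C(F)(F)F)cc2)sc2c1CCN(Cc1ccc(Cl)cc1Cl)C2`) gives 10900 nM as the only true number so far. Compound 3 (`NC(=O)c1c(NC(=O)c2ccccc2F)sc2c1CCN(Cc1ccc(Cl)cc1Cl)C2`) differs from compound 2 at one place, on a carbonyl carbon whose other neighbour is an amide-type nitrogen (2-fluorophenyl in place of 4-(trifluoromethyl)phenyl on a carbonyl carbon) with 2-fluorophenyl in place of 4-(trifluoromethyl)phenyl. For the measured compounds named here, the one measured step (an at least 4.5-fold lower number from compound 1 to compound 2 (0.66 log units; beyond the scatter)) is chloro in place of hydrogen on an aromatic carbon, which is a different place from this change. It shows only that one substitution can shift the number in this assay beyond the scatter, and it gives no direction for the present swap. The expected step (a 1.3-fold higher number from compound 2 to compound 3 (0.11 log units; within the scatter)) is estimated to stay within the scatter. Compound 3 is estimated at 14000 nM with an expected range from 5000 nM to 40000 nM as its likely span.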

Compound 3, half-maximal inhibitory concentration: 9610 nM
Beside the measured number, compound 3's estimate is 1.5-fold (0.16 log units) above it; the range from low to high includes it.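

In this assay, the swap of 4-(trifluoromethyl)phenyl for 2-fluorophenyl on a carbonyl carbon whose other neighbour is an amide-type nitrogen gives a 1.1-fold lower number from compound 2 to compound 3 (0.05 log units; within the scatter). Among the compounds shown here, this is the first reading at this position, and the aromatic group here can go from 10 heavy atoms to 7, with the trifluoromethyl giving way to a single fluorine, without a change beyond the scatter. The reading holds only with the chloro substituent that separates compound 2 from compound 1 in place, as compound 3 carries it too.

Open, going by these compounds, is whether an aminoalkyl chain or a carboxylic acid in place of the aromatic ring on this carbonyl carbon would shift the number beyond the scatter. The same swap without that chloro substituent also remains unresolved, as compound 1 is a limit of the assay and not a number: the limit of > 50000 nM in this assay, at which 1 of the 3 values shown sits.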